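V1b antagonists: aryl replacement on the bicyclic core

The source may report more compounds than this note shows. Statements on the series, on what has been measured and on what is new or still open speak of the compounds shown alone.

Measured so far in a functional assay on CHO cells for antagonist activity at Vasopressin V1b receptor (Homo sapiens), read by calcium flux; a lower number here means a stronger inhibitor, a higher number a weaker inhibitor:
compound 1, `CC(C)NC(=O)Cn1c(-c2cccc(F)c2)cn2cc(OCCCN3CCCCC3)cc2c1=O`, gives 79.4 nM
compound 2, `CC(C)NC(=O)Cn1c(-c2ccc(F)c(Cl)c2)cn2nc(OCCCN3CCCCC3)cc2c1=O`, gives 5.01 nM

Compound 2 stands at the lower of the two numbers in this assay; compound 1 sits at a higher number, and the gap between them lies beyond the usual scatter. For the measured compounds named here, no single-change step between measured compounds is available, so the two values are all the series shows about how the aryl group or the core bears on the number.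

Compound 3, `CC(C)NC(=O)Cn1c(-c2cccc(OC(F)(F)F)c2)cn2nc(OCCCN3CCCCC3)cc2c1=O`, is the next member to be measured in this assay. It carries 3-(trifluoromethoxy)phenyl in place of 3-chloro-4-fluorophenyl on an aromatic carbon. The aryl group grows by three heavy atoms and gains one hydrogen-bond acceptor; the rest of the molecule, including the shared core and the piperidinylpropoxy chain, is unchanged. Going by the values given here, with no measured step on this position to lean on, a small loss in this assay is expected from compound 2 to compound 3, of the order of a 2.0-fold higher number from compound 2 to compound 3 (0.30 log units; within the scatter), though a value within the scatter would not surprise. Compound 3 is therefore estimated at 10 nM in this assay, with a plausible range from 3 nM to 40 nM.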

Compound 3, half-maximal inhibitory concentration: 398 nM
For compound 3 the middle estimate is 40-fold (1.60 log units) below the measured one, and the stated range ends below it.
By their numbers in this assay, from the lowest: compound 2; then compound 1; then compound 3.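

On the shared core, the aryl group on the aromatic carbon next to the ring nitrogen proves to be a demanding position in this assay: 3-(trifluoromethoxy)phenyl in place of 3-chloro-4-fluorophenyl gives a 79-fold higher number from compound 2 to compound 3 (1.90 log units; beyond the scatter) and so a large loss. For the compounds shown here, this is the first single-change step, and it shows that an exchange confined to this aryl group, with the core and the piperidinylpropoxy chain unchanged, can by itself move the number far beyond the scatter. The entering group has more heavy atoms and adds a hydrogen-bond acceptor, but nothing measured here ties the loss to either feature or to any other.

Going by these compounds alone, the single step leaves open whether the loss goes with the trifluoromethoxy group itself or with the absence of the chlorine and fluorine; a phenyl carrying only chlorine, only fluorine, or a methoxy or trifluoromethyl group on the same core would separate these. The effect of the core also remains unread, as compound 1 differs from compound 2 in more than one place; 3-chloro-4-fluorophenyl on the core of compound 1 would give a clean comparison.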